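Notes on a small set of growth-inhibition compounds

The source may report more compounds than this note shows. Statements on the series, on what has been measured and on what is new or still open speak of the compounds shown alone.

Measured compounds
Compound 1, `COc1cc(/C=C/C(=O)c2cccc(-n3cc(-c4ccc(Cl)cc4)[nH]c3=O)c2)cc(OC)c1OC`: in a functional assay on T47D cells (Homo sapiens) for inhibition (on this read-out lower numbers stand for stronger inhibition of growth and higher numbers for weaker inhibition of growth), compound 1 gives 6650 nM.
Compound 2, `COc1ccc(-c2cn(-c3cccc(C(=O)/C=C/c4ccc(O)c(OC)c4)c3)c(=O)[nH]2)cc1`: in this assay compound 2 gives 3600 nM.
Compound 3, `COc1ccc(-c2cn(-c3cccc(C(=O)/C=C/c4cc(OC)c(OC)c(OC)c4)c3)c(=O)[nH]2)cc1`: in this assay compound 3 gives 3840 nM.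

The three numbers lie close together. The step of a 1.1-fold higher number from compound 2 to compound 3 (0.03 log units; within the scatter) and the step of a 1.7-fold higher number from compound 3 to compound 1 (0.24 log units; within the scatter) are each within the scatter, so no order among compound 1, compound 2 and compound 3 is claimed. Compound 3 and compound 1 differ by chloro in place of methoxy on an aromatic carbon, and that change gave a 1.7-fold higher number from compound 3 to compound 1 (0.24 log units; within the scatter). Compound 3 and compound 2 differ in the core by 4-hydroxy-3-methoxyphenyl in place of 3,4,5-trimethoxyphenyl on a double-bonded chain carbon bound to a double-bonded chain carbon, a change that gave a 1.1-fold higher number from compound 2 to compound 3 (0.03 log units; within the scatter).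

Compound 4, `COc1cc(/C=C/C(=O)c2cccc(-n3cc(-c4ccc(Cl)cc4)[nH]c3=O)c2)ccc1O`, is not yet measured. It differs from compound 2 by chloro in place of methoxy on an aromatic carbon, which is the same change, at the same place, as from compound 3 to compound 1. For the measured compounds named here, the only guide is that single earlier step of a 1.7-fold higher number from compound 3 to compound 1 (0.24 log units; within the scatter), seen once and within the scatter. The step from compound 2 to compound 4 is therefore expected to be small, around a 1.5-fold higher number from compound 2 to compound 4 (0.18 log units; within the scatter), resting on the step from compound 3 to compound 1. Compound 4 is expected near 5500 nM, between 2500 nM and 12000 nM.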

Compound 4, concentration for 50% growth inhibition: 3090 nM
Estimate against measurement, compound 4: 1.8-fold (0.25 log units) above, within the range that was stated.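

Chloro in place of methoxy, read here as 4-methoxyphenyl to 4-chlorophenyl, gave a 1.2-fold lower number from compound 2 to compound 4 (0.07 log units; within the scatter) in this assay. For the compounds shown here, with only two cores and both steps within the scatter, the data show neither a consistent effect that carries from one core to the other nor an effect that depends on the core, and no direction can be assigned to this change. What can be said is that neither step leaves the scatter and that the two steps do not differ from each other: the same change on two cores in this assay, a 1.7-fold higher number (0.24 log units; within the scatter) from compound 3 to compound 1 and a 1.2-fold lower number (0.07 log units; within the scatter) from compound 2 to compound 4, 2.0-fold (0.30 log units) apart, within the scatter of two such steps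

The compounds shown carry only methoxy and chloro at this place, which leaves open how an amine, a carboxylic acid or a longer alkyl chain there would read out in this assay. Also open, as far as these compounds go, is whether the chloro-for-methoxy step would stay within the scatter on a third core, for instance one with a carboxylic acid on the ring now held by 4-hydroxy-3-methoxyphenyl or 3,4,5-trimethoxyphenyl.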